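Working notes on cytotoxicity in a small series

The source may report more compounds than this note shows. Statements on the series, on what has been measured and on what is new or still open speak of the compounds shown alone.

Measured so far:
Compound 1 `COc1cccc([C@H]2CC(C)(O)[C@@H]3CC[C@@H](C)C[C@H]3O2)c1OC` gives > 937000 nM, a limit of the assay.
Compound 2 `COc1ccc([C@H]2CC(C)(O)[C@@H]3CC[C@@H](C)C[C@H]3O2)c(OC)c1OC` gives > 857000 nM, again a limit.
Going by the values given here, compound 3 `C[C@@H]1CC[C@@H]2[C@@H](C1)O[C@@H](c1ccc(O)cc1)CC2(C)F` gives 95000 nM, the only number in the set.

The read-out throughout is an ADME assay on MDCK cells (Canis lupus familiaris) for cytotoxicity, read by MTT assay, with a stated time of 48 h; on this read-out lower numbers stand for higher toxicity in this test and higher numbers for lower toxicity in this test. Compound 1 and compound 2 differ by methoxy in place of hydrogen on an aromatic carbon, and the step is a step that the two limits leave unreadable from compound 1 to compound 2; both values rest on the limit of > 857000 nM in this assay, at which 1 of the 3 values shown sits, and (the limit of > 937000 nM in this assay, at which 1 of the 3 values shown sits), so the size of this step cannot be read. Among the compounds with values here, compound 3 is the only compound of the three with a number in this assay; how its core differs from that of compound 1 is not broken down here.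

Compound 4 `COc1cc([C@H]2CC(C)(F)[C@@H]3CC[C@@H](C)C[C@H]3O2)ccc1O` is not yet measured. It differs from compound 3 by methoxy in place of hydrogen on an aromatic carbon. Within the data shown here, this is the same kind of change as the one from compound 1 to compound 2, but the surroundings differ: in compound 4 the new group sits ortho to a hydroxy group and meta to a large group, whereas in compound 2 it sits ortho to a methoxy group, meta to a methoxy group and para to a large group.

The measured step gives no readable size, so the expectation for compound 4 rests on compound 3 alone, whose value 95000 nM is taken as the anchor. The step from compound 3 to compound 4 is expected to be no change at the digits printed from compound 3 to compound 4 (within the scatter). Compound 4 is therefore estimated at 95000 nM, with a range from 40000 nM to 250000 nM.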

Compound 4, half-maximal cytotoxic concentration: 642000 nM
For compound 4 the middle estimate is 6.8-fold (0.83 log units) below the measured one; the measured number lies above the stated range.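

In this assay, methoxy in place of hydrogen on an aromatic carbon gives a 6.8-fold higher number from compound 3 to compound 4 (0.83 log units; beyond the scatter), so on the core of compound 3, with the new group ortho to a hydroxy group and meta to a large group, the change has a readable size. This is one step on one core, and it shows nothing about the direction or size of the same change on another core. The only counterpart, from compound 1 to compound 2, cannot be read, since the values at both of its ends are limits of the assay and not numbers: the limit of > 857000 nM in this assay, at which 1 of the 4 values shown sits.

The compounds shown leave open whether an amine or a carboxylic acid at the same place on the core of compound 3 would give a step like this one. They also leave open whether methoxy at that place on the core of compound 1 would give a readable number at all.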